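Cyclopentyl for Isobutyl on the Purine Riboside Core

This account rests on a few compounds, and the source may have more. Where it says the series, first, only, none or still open, it means among the compounds named here.

The measured compounds in a functional assay on CCRF-CEM cells (Homo sapiens) for cytotoxicity, with a stated time of 72 h; on this read-out higher numbers stand for weaker inhibition and lower numbers for stronger inhibition:

compound 1, `CCCc1ncnc2c1ncn2[C@@H]1O[C@H](CO)[C@@H](O)[C@H]1O`, with 6800 nM
compound 2, `CC(C)Cc1ncnc2c1ncn2[C@@H]1O[C@H](CO)[C@@H](O)[C@H]1O`, with > 130000 nM, a limit of the assay
compound 3, `OC[C@H]1O[C@@H](n2cnc3c(C4CC4)ncnc32)[C@H](O)[C@@H]1O`, with 1000 nM

Compound 2 stands at the limit of > 130000 nM in this assay, at which 1 of the 3 values shown sits, so for compound 2 only a limit is known, and its step to any other compound can be given only as a bound. The change that leads from compound 2 to compound 4, `OC[C@H]1O[C@@H](n2cnc3c(C4CCCC4)ncnc32)[C@H](O)[C@@H]1O`, is cyclopentyl in place of isobutyl on an aromatic carbon.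

For the measured compounds named here, two measured steps bear on this. The step of an at least 130-fold lower number from compound 2 to compound 3 (2.11 log units; beyond the scatter) shows that a carbocyclic group in place of isobutyl at this position lowers the number greatly, though the ring there was three-membered. The step of an at least 19-fold higher number from compound 1 to compound 2 (1.28 log units; beyond the scatter) shows that branching of the chain at the carbon bound to two other saturated chain carbons raises the number greatly. Cyclopentyl removes the branched chain, but is larger than cyclopropyl, and no measured compound tells how a five-membered ring fares here.

In this assay compound 4 is therefore expected to lie at about 2500 nM, between 300 nM and 25000 nM. This estimate means a step of an at least 52-fold lower number from compound 2 to compound 4 (1.71 log units; beyond the scatter), a large improvement from the limit, but with wide uncertainty.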

Compound 4, half-maximal inhibitory concentration: 16000 nM
Compound 4: middle estimate off by 6.4-fold (0.81 log units), on the low side; low and high end bracket the measured number.
By their numbers in this assay, from the lowest: compound 3; then compound 1; then compound 4. At a limit, above all of these: compound 2.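

In this assay, a ring at this aromatic carbon does not by itself keep the low number of the three-membered ring, and ring size clearly matters, with a 16-fold higher number from compound 3 to compound 4 (1.20 log units; beyond the scatter). Cyclopentyl also fails to improve on the open propyl chain, with a 2.4-fold higher number from compound 1 to compound 4 (0.37 log units; beyond the scatter), so among the compounds with a measured number, only cyclopropyl improves on propyl. Cyclopentyl still does better than isobutyl, with an at least 8.1-fold lower number from compound 2 to compound 4 (0.90 log units; beyond the scatter), but this step is only a bound, since compound 2 is known only as a limit: the limit of > 130000 nM in this assay, at which 1 of the 4 values shown sits.

The compounds shown leave open how cyclobutyl or cyclohexyl would fare at this position, so it remains unclear whether the number climbs steadily with ring size or whether cyclopropyl is a special case. They also leave open whether a ring carrying atoms other than carbon, such as a morpholine, or a flat phenyl group would behave like these carbon groups, and whether a straight butyl chain would share the weak result of branched isobutyl.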